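The source may hold more compounds than are shown below. What is called first, only, known or untested is meant among the compounds shown, and "the series" means these compounds.

Measured in a functional assay on HL-60 cells (Homo sapiens) for inhibition, read by CCK-8 assay, with a stated time of 48 h, tested at 20 uM; a higher number here means more inhibition of growth at the concentration tested, a lower number less inhibition of growth:
- compound 1 `N#C/C(=C\c1ccccc1OS(=O)(=O)c1ccccc1[N+](=O)[O-])C(=O)Nc1nnc(Cc2ccccc2)s1`: 12%
- compound 2 `N#C/C(=C\c1ccccc1OS(=O)(=O)c1ccc(Cl)cc1)C(=O)Nc1nnc(Cc2ccccc2)s1`: 26%
- compound 3 `N#C/C(=C\c1ccccc1OS(=O)(=O)c1ccc(F)cc1)C(=O)Nc1nnc(Cc2ccccc2)s1`: 22%

Compound 3, at 22%, lies within the usual scatter of the other two compounds. The data show a number 4 percentage points lower from compound 2 to compound 3 (within the scatter) and a number 10 percentage points higher from compound 1 to compound 3 (within the scatter). Only a number 14 percentage points higher from compound 1 to compound 2 (beyond the scatter) goes beyond the scatter, and that step is modest.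

Compound 4 `N#C/C(=C\c1ccccc1OS(=O)(=O)c1ccc(F)cc1)C(=O)Nc1nnc(Cc2ccc(F)cc2)s1` differs from compound 3 only in its benzyl group, which becomes 4-fluorobenzyl: fluoro in place of hydrogen on an aromatic carbon. Among the compounds with values here, no measured step touches this ring. All three fall on the aryl group attached to the sulfonyl sulfur. The closest in kind is a number 4 percentage points lower from compound 2 to compound 3 (within the scatter), which also concerns a fluoro on an aromatic carbon. It is only a loose guide, though, as there fluoro replaced chloro rather than hydrogen, and on a different ring. No change beyond the scatter is therefore expected, and the data give no firm direction. The expected size of the change is a number 2 percentage points higher from compound 3 to compound 4 (within the scatter). For compound 4 the estimated value is 24%, with an expected range from 12% to 38%.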

Compound 4, percent growth inhibition at one concentration: 13%
For compound 4 the middle estimate is 11 percentage points above the measured one, within the range that was stated.
By their numbers in this assay, from the lowest: compounds 1, 4, 3 and 2 (each within the scatter of the next, the first and the last beyond it).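

Among the compounds shown, only compound 4 carries a change on the benzyl group, while the others differ on the aryl group attached to the sulfonyl sulfur. In this assay the step is a number 9 percentage points lower from compound 3 to compound 4 (within the scatter) and shows that, in this pair, fluoro in place of hydrogen on this ring does not separate the two compounds beyond the usual scatter. No measurement shown here helps to explain this result.

Fluoro is the only group shown on this ring, so a methoxy group or an amine in that place could behave differently. Going by these compounds, it also remains open whether replacing the benzyl group with a longer chain, such as phenylethyl, would give a step beyond the scatter.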